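Notes on the ether group in a small inhibitor series

The source may report more compounds than this note shows. Statements on the series, on what has been measured and on what is new or still open speak of the compounds shown alone.

Measured so far, in a functional assay on J774.A1 cells (Mus musculus) for inhibition, read by Griess assay, with stated times of 1 h and 24 h; a lower number here means a stronger inhibitor, a higher number a weaker inhibitor:
compound 1 `O=C1CC(c2ccccc2OCc2ccccc2)Oc2ccccc21` gives 23200 nM;
compound 2 `COCOc1ccccc1C1CC(=O)c2ccccc2O1` gives 35200 nM;
compound 3 `O=C1CC(c2ccccc2OCc2ccc(F)cc2)Oc2ccccc21` gives 25500 nM.

Compound 3 stands second highest of the three numbers. Its steps to the other two, a 1.1-fold higher number from compound 1 to compound 3 (0.04 log units; within the scatter) and a 1.4-fold lower number from compound 2 to compound 3 (0.14 log units; within the scatter), are both within the scatter, so the three compounds cannot be ordered on these data.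

Compound 4 `CC(C)COc1ccccc1C1CC(=O)c2ccccc2O1` differs from compound 3 in one place: isopropyl in place of 4-fluorophenyl on a saturated chain carbon bound to an oxygen on an aromatic ring.

Among the measured compounds shown here, two measured steps bear on this change, as both swap the group on the same saturated chain carbon bound to an oxygen on the aromatic ring: a 1.5-fold higher number from compound 1 to compound 2 (0.18 log units; within the scatter), where methoxy replaces phenyl, and a 1.4-fold lower number from compound 2 to compound 3 (0.14 log units; within the scatter), where 4-fluorophenyl replaces methoxy. Both lie within the scatter, and the replacement of an aromatic group by a small saturated one gave at most a slight rise. For compound 4 a step of a 1.2-fold higher number from compound 3 to compound 4 (0.08 log units; within the scatter) in this assay is therefore expected, not beyond the scatter. Compound 4 is estimated at 31000 nM, with a range of 15000 nM to 65000 nM.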

Compound 4, half-maximal inhibitory concentration: 33200 nM
Estimate against measurement, compound 4: 1.1-fold (0.03 log units) below; the range from low to high includes it.
By their numbers in this assay, from the lowest: compounds 1, 3, 4 and 2 (each within the scatter of the next).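

In this assay, isopropyl adds a saturated group of carbon only to the groups seen at this place, and all three steps to it stay within the scatter: a 1.3-fold higher number from compound 3 to compound 4 (0.11 log units; within the scatter), a 1.4-fold higher number from compound 1 to compound 4 (0.16 log units; within the scatter) and a 1.1-fold lower number from compound 2 to compound 4 (0.03 log units; within the scatter). On a saturated chain carbon bound to an oxygen on an aromatic ring, phenyl, 4-fluorophenyl, methoxy and isopropyl therefore cannot be told apart, and the presence of an aromatic ring in this group makes no readable difference among compounds 1 to 4. No measurement at hand offers an explanation for this flat result.

Still open, on these data alone, is whether an amine, a carboxylic acid or a longer chain at this place would give a step beyond the scatter. Also open, as far as these compounds go, is whether a change to the shared core would do so.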